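Vero cytotoxicity notes: heteroaryl amide change at the amide nitrogen

The source may hold more compounds than are shown below. What is called first, only, known or untested is meant among the compounds shown, and "the series" means these compounds.

Measured so far:
- compound 1 `O=C(NCCO)c1cccc2[nH]c(-c3ccncc3)nc12`: 498 uM
- compound 2 `CCC(CC)NC(=O)c1cccc2[nH]c(-c3ccc(OC)c(OC)c3)nc12`: 2.23 uM
- compound 3 `COc1ccc(-c2nc3c(C(=O)Nc4ncc[nH]4)cccc3[nH]2)cc1OC`: "not active" (no number reported), without a number

In an ADME assay on Vero cells (Chlorocebus sabaeus) for cytotoxicity (on this read-out lower numbers stand for higher toxicity in this test and higher numbers for lower toxicity in this test), compound 1 gives 498 uM and compound 2 gives 2.23 uM. Within the data shown here, compound 3 stands apart from both: in this assay compound 3 was reported only as "not active" (no number reported), so no single number places it, and no step to compound 1 or compound 2 can be read from it. Compound 4 `COc1ccc(-c2nc3c(C(=O)Nc4ncccc4O)cccc3[nH]2)cc1OC` is not yet measured in this assay. It differs from compound 3 only by 3-hydroxypyridin-2-yl in place of 1H-imidazol-2-yl on an amide-type nitrogen, the amide with an aryl-substituted core otherwise unchanged. Among the measured compounds shown here, with no measured pair that differs in one place, the size of this step cannot be taken from the data; the expectation rests on compound 3 showing no toxicity in this assay and compound 1, the other small amide, giving 498 uM. Compound 4 is therefore expected to show low toxicity, with an estimated half-maximal toxic concentration of 200 uM and a range of 40 uM to 1000 uM, and a fair chance that the assay again reports only a limit.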

Compound 4, half-maximal toxic concentration: 164 uM
Compound 4: middle estimate off by 1.2-fold (0.09 log units), on the high side, within the range that was stated.
By their numbers in this assay, from the lowest: compound 2; then compound 4; then compound 1.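

In this assay, among these compounds, compound 4 gives 164 uM and is the first compound here with a ring on the amide-type nitrogen to carry a number. On the shared core, 3-hydroxypyridin-2-yl in place of pentan-3-yl gives a 74-fold higher number from compound 2 to compound 4 (1.87 log units; beyond the scatter), a large step beyond the usual scatter, so the read-out in this series responds strongly to the group at this nitrogen. The step between compound 3 and compound 4 cannot be read, as compound 3 has no number, and no measurement shown offers a reason for the step that can be read.

On these data alone, how a plain pyridin-2-yl or a 3-methoxypyridin-2-yl would read on the same nitrogen remains open, leaving the part played by the hydroxyl unsettled. Also open, as far as these compounds go, is where a 2-hydroxyethyl or 2-aminoethyl chain on this nitrogen would fall on the shared core.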